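The source may report more compounds than this note shows. Statements on the series, on what has been measured and on what is new or still open speak of the compounds shown alone.

Measured compounds in an assay on isolated protein for inhibition of acyl-CoA:cholesterol acyltransferase (Oryctolagus cuniculus); a lower number here means a stronger inhibitor, a higher number a weaker inhibitor:
Compound 1 `CCCCCCCCCCCCCCc1ccc(NC(=O)Nc2c(C(C)C)cccc2C(C)C)cc1` gives 500 nM.
Compound 2 `CCCCCCCCCCCCCc1ccc(NC(=O)Nc2c(C(C)C)cccc2C(C)C)cc1` gives 11 nM.
Compound 3 `CCCCCCc1ccc(NC(=O)Nc2c(C(C)C)cccc2C(C)C)cc1` gives 26 nM.

Among these three, compound 3 stands second highest: it lies close to compound 2, as a 2.4-fold higher number from compound 2 to compound 3 (0.37 log units; beyond the scatter) shows, and far below compound 1, as a 19-fold lower number from compound 1 to compound 3 (1.28 log units; beyond the scatter) shows. Compound 4 `CCCCCCCCCCCCc1ccc(NC(=O)Nc2c(C(C)C)cccc2C(C)C)cc1` is not yet measured; it carries hexyl in place of hydrogen on a saturated chain carbon, six bonds along the chain from an aromatic carbon. Among the measured compounds shown here, two measured steps bear on this. Read backwards, a 2.4-fold higher number from compound 2 to compound 3 (0.37 log units; beyond the scatter) says that a much longer chain gives a modest gain, while a 45-fold lower number from compound 1 to compound 2 (1.66 log units; beyond the scatter) says that one methyl too many costs heavily. Compound 4 stops short of both chain lengths, so a modest lowering is expected, a 1.7-fold lower number from compound 3 to compound 4 (0.24 log units; within the scatter). The estimate for compound 4 in this assay is 15 nM, within a range from 5 nM to 50 nM.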

Compound 4, half-maximal inhibitory concentration: 15 nM
Compound 4: middle estimate and measured number agree at the digits printed, within the range that was stated.
By their numbers in this assay, from the lowest: compounds 2, 4 and 3 (each within the scatter of the next, the first and the last beyond it); then compound 1.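

In this assay, hexyl in place of hydrogen at this chain carbon leaves the number within the scatter (a 1.7-fold lower number from compound 3 to compound 4 (0.24 log units; within the scatter)), and so does removing a methyl from the chain end (a 1.4-fold higher number from compound 2 to compound 4 (0.13 log units; within the scatter)). Compound 4 is thus within the scatter of both its shorter and longer neighbours, yet the change that adds ethyl to it, read backwards, is large (a 33-fold lower number from compound 1 to compound 4 (1.52 log units; beyond the scatter)). Nothing available explains this abrupt loss. Still open, going by these compounds, is how a butyl chain, or an amine or carboxylic acid at the chain end, would read in this assay.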